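The compounds below may be only part of what the source reports. "The series", "measured", "known", "first", "only" and "open" are said of these compounds alone.

Measured in a functional assay on SW480 cells (Homo sapiens) for cytotoxicity, read by MTT assay, with a stated time of 48 h; a higher number here means a weaker inhibitor, a lower number a stronger inhibitor:

- compound 1, `O=c1ccoc2cc(OCc3cn(Cc4cccc(Br)c4)nn3)ccc12`: > 100000 nM, a limit of the assay
- compound 2, `CC(C)(C)c1ccc(Cn2cc(COc3ccc4c(=O)ccoc4c3)nn2)cc1`: 28800 nM
- compound 3, `O=c1ccoc2cc(OCc3cn(Cc4cccc([N+](=O)[O-])c4)nn3)ccc12`: > 100000 nM, a limit of the assay

Compound 1 stands only at a limit in this assay; no number is known for it. Compound 3 likewise sits at a limit. Two of the three values shown are limits: the limit of > 100000 nM in this assay, at which 2 of the 3 values shown sit. For the measured compounds named here, compound 2 is the only member with a number, and it differs from compound 1 in more than one place, so it shows only where a number has been reached.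

The step to compound 4, `O=c1ccoc2cc(OCc3cn(Cc4cccc(Cl)c4)nn3)ccc12`, changes compound 1 in one place: chloro in place of bromo on an aromatic carbon. Going by the values given here, the only measured step that starts from compound 1 is a step that the two limits leave unreadable from compound 1 to compound 3, which the two limits leave unreadable, so it gives no size to carry over. Among the compounds with values here, no step between bromo and chloro has been measured. Compound 4 is expected to remain at the limit, with an estimated step that the limit leaves unreadable from compound 1 to compound 4. Compound 4 is estimated at 120000 nM, in the range 40000 nM to 400000 nM, with a good chance that this assay again reports only a limit.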

Compound 4, half-maximal inhibitory concentration: 12900 nM
The estimate for compound 4 lay 9.3-fold (0.97 log units) above the measured number; the measured number lies below the stated range.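

In this assay, for the compounds shown here, the change to the 3-chlorobenzyl group gives the first readable steps at this position: an at least 7.7-fold lower number from compound 1 to compound 4 (0.88 log units; beyond the scatter), with chloro in place of bromo on the same aromatic carbon, and an at least 7.7-fold lower number from compound 3 to compound 4 (0.88 log units; beyond the scatter), with chloro in place of nitro. Among compounds 1, 3 and 4, the group on this one carbon therefore separates a measured number from the limit, with chloro the only one of the three to give a number. Both steps give only a minimum size, because neither compound 1 nor compound 3 has a number: the limit of > 100000 nM in this assay, at which 2 of the 4 values shown sit.

Going by these compounds, how fluoro, methoxy or an amine on this aromatic carbon would read remains open. Also open, on these data alone, is whether chloro on another carbon of the same ring would keep a measurable number.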